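Acetyl versus methylsulfonyl on two related cores

The source may hold more compounds than are shown below. What is called first, only, known or untested is meant among the compounds shown, and "the series" means these compounds.

Compound 1 `CC(=O)c1coc(C(=O)CCCCCCc2ccccc2)n1` carries an acetyl group on its core. In an assay on HEK-293T cells for inhibition of diacylglycerol lipase-alpha (Homo sapiens), read by colorimetric assay (on this read-out lower numbers stand for stronger inhibition and higher numbers for weaker inhibition), compound 1 gives 123 nM. Compound 2 `CS(=O)(=O)c1coc(C(=O)CCCCCCc2ccccc2)n1` differs from it by methylsulfonyl in place of acetyl on an aromatic carbon and in this assay compound 2 gives 389 nM, the step being a 3.2-fold higher number from compound 1 to compound 2 (0.50 log units; beyond the scatter). Compound 3 `CC(=O)c1cnc(C(=O)CCCCCCc2ccccc2)o1` has the same atoms as compound 1, joined differently, and the difference between the two cores is not broken down here. In this assay compound 3 reaches only a limit of the assay, > 10000 nM, not a number. Compound 4 `CS(=O)(=O)c1cnc(C(=O)CCCCCCc2ccccc2)o1` is not yet measured and differs from compound 3 by methylsulfonyl in place of acetyl on an aromatic carbon. This is the same kind of change as that from compound 1 to compound 2, but the place differs: in compound 4 the group sits next to the ring oxygen, two ring bonds from the ring nitrogen, whereas in compound 2 it sits next to the ring nitrogen, two ring bonds from the ring oxygen. Among the compounds with values here, for compound 4 a step that the limit leaves unreadable from compound 3 to compound 4 is expected, resting on a 3.2-fold higher number from compound 1 to compound 2 (0.50 log units; beyond the scatter) as the single measured instance of the change and on the limit of > 10000 nM in this assay, at which 1 of the 3 values shown sits, for compound 3, from which any number can only move away from the limit. Compound 4 is therefore expected to give about 30000 nM, most likely again only a limit.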

Compound 4, half-maximal inhibitory concentration: > 10000 nM
Compound 4: no number, only a limit; the forecaster's own chance of this, stated with the estimate: 85%; the middle value lies beyond the limit too.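

Compound 3 and compound 4 both sit at a limit in this assay, not at a number, so no step between them can be read: the limit of > 10000 nM in this assay, at which 2 of the 4 values shown sit.

What the compounds shown leave open is whether methylsulfonyl in place of acetyl changes inhibition on the core of compound 3 as it does on the core of compound 1.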